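Cytotoxicity of benzoyl and pyridinoyl analogues on HEK-293T cells

A few compounds are considered here, and "the series" means these few. Any claim that something is new, unique, unknown or untested is made for them only; others in the source may bear on it.

Compound 1 `Cc1cncc(C(=O)n2c(-c3cn(-c4ccccc4)nc3-c3ccc(F)cc3)nc3ccccc32)c1` gives 119000 nM in an ADME assay on HEK-293T cells (Homo sapiens) for cytotoxicity, read by MTT assay, with a stated time of 24 h; a lower number here means that less compound is tolerated, a higher number that more compound is tolerated. Compound 2 `O=C(c1ccccc1)n1c(-c2cn(-c3ccccc3)nc2-c2ccc(F)cc2)nc2ccccc21`, which differs by phenyl in place of 5-methylpyridin-3-yl on a carbonyl carbon, gives 180000 nM; the step is a 1.5-fold higher number from compound 1 to compound 2 (0.18 log units; within the scatter). Compound 3 `Cc1cncc(C(=O)n2c(-c3cn(-c4ccccc4)nc3-c3ccc(C(F)(F)F)cc3)nc3ccccc32)c1` differs from compound 1 by trifluoromethyl in place of fluoro on an aromatic carbon; in this assay compound 3 gives 123000 nM, a step of a 1.0-fold higher number from compound 1 to compound 3 (0.01 log units; within the scatter). Compound 4 `O=C(c1ccccc1)n1c(-c2cn(-c3ccccc3)nc2-c2ccc(C(F)(F)F)cc2)nc2ccccc21` has not been measured; it differs from compound 3 by phenyl in place of 5-methylpyridin-3-yl on a carbonyl carbon. This is the same kind of change as that from compound 1 to compound 2. Since that change gave a 1.5-fold higher number from compound 1 to compound 2 (0.18 log units; within the scatter), a step of similar size is expected from compound 3 to compound 4, namely a 1.5-fold higher number from compound 3 to compound 4 (0.17 log units; within the scatter). Compound 4 is therefore estimated at 180000 nM, with an expected range from 100000 nM to 320000 nM.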

Compound 4, half-maximal cytotoxic concentration: 168000 nM
Estimate against measurement, compound 4: 1.1-fold (0.03 log units) above, and the stated range covers the measured number.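

In this assay phenyl in place of 5-methylpyridin-3-yl on a carbonyl carbon gives a 1.4-fold higher number from compound 3 to compound 4 (0.14 log units; within the scatter) and reads alike on the two cores: the same change on two cores in this assay, a 1.5-fold higher number (0.18 log units; within the scatter) from compound 1 to compound 2 and a 1.4-fold higher number (0.14 log units; within the scatter) from compound 3 to compound 4, 1.1-fold (0.04 log units) apart, within the scatter of two such steps. Trifluoromethyl in place of fluoro on an aromatic carbon gives a 1.1-fold lower number from compound 2 to compound 4 (0.03 log units; within the scatter) and also reads alike on both: the same change on two cores in this assay, a 1.0-fold higher number (0.01 log units; within the scatter) from compound 1 to compound 3 and a 1.1-fold lower number (0.03 log units; within the scatter) from compound 2 to compound 4, 1.1-fold (0.04 log units) apart, within the scatter of two such steps. Every one of these steps lies within the scatter, so the four compounds show that neither change moved the number measurably on these two cores, but they do not show that either change has an effect of its own or that this agreement holds on any other core. As far as these compounds go, whether an amine or a carboxylic acid in place of trifluoromethyl would leave the number where it stands remains open. The same is true of a longer chain in place of phenyl on the carbonyl carbon.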